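The compounds below may be only part of what the source reports. "The series", "measured", "known", "first", "only" and "open" are said of these compounds alone.

Of the compounds shown here, three sharing one core have been tested in a functional assay on MDA-MB-231 cells (Homo sapiens) for antiproliferative activity, read by MTT assay, with a stated time of 72 h; a higher number here means a weaker inhibitor, a lower number a stronger inhibitor. Compound 1 `CC(=O)Nc1ccc(S(=O)(=O)Nc2cccc(-c3nc(-c4ccc(NC(=O)c5cccnc5)cc4Cl)no3)c2)cc1Cl` gives only a limit of the assay, > 10000 nM. Compound 2 `CCN(CC)C(=O)Nc1ccc(S(=O)(=O)Nc2cccc(-c3nc(-c4ccc(NC(=O)c5cccnc5)cc4Cl)no3)c2)cc1` gives 8700 nM. Compound 3 `O=C(Nc1ccccc1)Nc1cccc(-c2nc(-c3ccc(NC(=O)c4cccnc4)cc3Cl)no2)c1` likewise gives only a limit, > 10000 nM. Compound 3 thus sits at the edge of what this assay reports, and the limit of > 10000 nM in this assay, at which 2 of the 3 values shown sit, shows that the same edge holds for compound 1 as well. Compound 4 `CC(=O)Nc1ccc(NC(=O)Nc2cccc(-c3nc(-c4ccc(NC(=O)c5cccnc5)cc4Cl)no3)c2)cc1Cl` differs from compound 3 in one place: 4-acetamido-3-chlorophenyl in place of phenyl on an amide-type nitrogen. Among the compounds with values here, no measured pair isolates this change, so no step size can be read from the data. Compound 1, which carries the entering group on a related sulfonamide, gives > 10000 nM, again a limit. Compound 4 is expected to remain weak, with the step that the limit leaves unreadable from compound 3 to compound 4 estimated as none beyond the scatter and a value estimated at 15000 nM, ranging from 5000 nM to 50000 nM.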

Compound 4, half-maximal inhibitory concentration: > 10000 nM
Compound 4 gave a limit, no number; the forecaster's own chance of this, stated with the estimate: 60%; the middle value lies beyond the limit too.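

Compound 3 and compound 4 both sit at the same edge of this assay, so no step can be read between them; that edge is a limit, not a number: the limit of > 10000 nM in this assay, at which 3 of the 4 values shown sit.

The compounds shown leave open whether 4-acetamido-3-chlorophenyl in place of phenyl changes antiproliferative activity at all.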